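Swapping an octyl chain for a difluorophenyl ring

The source may report more compounds than this note shows. Statements on the series, on what has been measured and on what is new or still open speak of the compounds shown alone.

Compound 1 `O=c1cc(Cn2cc(CCO)nn2)c2ccc(O)cc2o1`: > 100000 nM
Compound 2 `CCCCCCCCc1cn(Cc2cc(=O)oc3cc(O)ccc23)nn1`: 50900 nM

In a functional assay on SW-620 cells (Homo sapiens) for inhibition, read by MTT assay, with a stated time of 72 h (a higher number here means a weaker inhibitor, a lower number a stronger inhibitor), compound 2 gives 50900 nM, the only number shown. Compound 1 reaches only a limit, > 100000 nM (the limit of > 100000 nM in this assay, at which 1 of the 2 values shown sits). Within the data shown here, the one measured step, an at least 1.9-fold lower number from compound 1 to compound 2 (0.29 log units; that floor lies within the scatter), lies within the scatter. Compound 3 `O=c1cc(Cn2cc(-c3cc(F)cc(F)c3)nn2)c2ccc(O)cc2o1` differs from compound 2 by 3,5-difluorophenyl in place of octyl on an aromatic carbon. Among the measured compounds shown here, no measured step replaces a chain by an aromatic ring, so that step gives no guide beyond the scatter. Compound 3 is therefore expected to stay near compound 2, with an estimated 1.3-fold lower number from compound 2 to compound 3 (0.10 log units; within the scatter) and a value of 40000 nM in a range of 10000 nM to 150000 nM.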

Compound 3, half-maximal inhibitory concentration: 66700 nM
Compound 3: the middle estimate sits 1.7-fold (0.22 log units) below what was measured; low and high end bracket the measured number.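

On this aromatic carbon, an aromatic ring can take the place of a saturated chain without a readable change: replacing octyl with 3,5-difluorophenyl gives a 1.3-fold higher number from compound 2 to compound 3 (0.12 log units; within the scatter). Against 2-hydroxyethyl, the same ring gives an at least 1.4-fold lower number from compound 1 to compound 3 (0.17 log units; that floor lies within the scatter). That step is only a floor, because compound 1 reaches a limit and not a number: the limit of > 100000 nM in this assay, at which 1 of the 3 values shown sits.

Still open, as far as these compounds go, is whether any group on this carbon can move the number beyond the scatter. A plain phenyl ring, an amine, a carboxylic acid or a longer chain could each test this.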